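Replacing 4-(ethoxycarbonyl)piperazin-1-yl with piperidin-1-yl: an expected small step

This account rests on a few compounds, and the source may have more. Where it says the series, first, only, none or still open, it means among the compounds named here.

Results in a functional assay on MCF7 cells (Homo sapiens) for inhibition, read by MTT assay, with a stated time of 48 h, tested at 10 uM (on this read-out higher numbers stand for more inhibition of growth at the one concentration tested and lower numbers for less inhibition of growth), are available for three compounds:
Compound 1 `Cc1cc(=O)c2c(O)c(CN3CCC(N4CCCCC4)CC3)c(O)c([C@H]3CCN(C)C[C@H]3O)c2o1` gives 25%
Compound 2 `Cc1cc(=O)c2c(O)c(CN3CCC(Cc4ccccc4)CC3)c(O)c([C@H]3CCN(C)C[C@H]3O)c2o1` gives 17%
Compound 3 `CCOC(=O)N1CCN(Cc2c(O)c([C@H]3CCN(C)C[C@H]3O)c3oc(C)cc(=O)c3c2O)CC1` gives 31%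

Compound 3 (31%) sits within the usual scatter of compound 1 (25%). Compound 2 gives 17%, and the gap between it and compound 3 lies beyond the usual scatter. Compound 4 (`Cc1cc(=O)c2c(O)c(CN3CCCCC3)c(O)c([C@H]3CCN(C)C[C@H]3O)c2o1`) has not yet been measured. It differs from compound 3 by piperidin-1-yl in place of 4-(ethoxycarbonyl)piperazin-1-yl on a saturated chain carbon bound to an aromatic carbon.

Within the data shown here, no measured step makes this exact change. The only one available is benzyl in place of piperidin-1-yl on a saturated ring carbon, which gave a number 8 percentage points lower from compound 1 to compound 2 (within the scatter) and so offers only indirect guidance. Among the measured compounds shown here, all three measured compounds carry a different group on the same chain carbon, and their values give the only frame for compound 4. In this assay, for the measured compounds named here, a modest fall is therefore expected, with no step clearly beyond the scatter (estimated: a number 7 percentage points lower from compound 3 to compound 4 (within the scatter)). For compound 4 the estimated value is 24% (expected range 12% to 36%).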

Compound 4, percent growth inhibition at one concentration: 15%
Compound 4: middle estimate off by 9 percentage points, on the high side; low and high end bracket the measured number.
By their numbers in this assay, from the lowest: compounds 4, 2, 1 and 3 (each within the scatter of the next, the first and the last beyond it).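

In this assay, among these compounds, the change at the saturated chain carbon bound to an aromatic carbon, piperidin-1-yl in place of 4-(ethoxycarbonyl)piperazin-1-yl, gives a number 16 percentage points lower from compound 3 to compound 4 (beyond the scatter), the first single-place step in this set to lie beyond the usual scatter. This shows that the group at this position can shift the read-out measurably, which the earlier step, made further out on a saturated ring carbon, did not show. On that ring carbon, hydrogen in place of benzyl gives a number 2 percentage points lower from compound 2 to compound 4 (within the scatter), and hydrogen in place of piperidin-1-yl gives a number 10 percentage points lower from compound 1 to compound 4 (within the scatter), so neither substituent separates from the bare piperidin-1-yl compound. Nothing available explains the size of the step from compound 3 to compound 4.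

The compounds shown do not tell whether the ethoxycarbonyl group or the second ring nitrogen accounts for that step, a question that an unsubstituted piperazin-1-yl group or a morpholin-4-yl group at the same carbon would address. They also leave open whether the step would hold at other concentrations, since every reading comes from a single one.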